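Exchanging the Amide Nitrogen Substituent and Expected Cytotoxicity

The source may hold more compounds than are shown below. What is called first, only, known or untested is meant among the compounds shown, and "the series" means these compounds.

Compound 1: `CS(=O)(=O)Nc1ccc2c(c1)S(=O)(=O)N=C(C1=C(O)C3CCCC3N(Cc3ccccn3)C1=O)N2`. In an ADME assay on Huh-7 cells (Homo sapiens) for cytotoxicity, with a stated time of 72 h (on this read-out higher numbers stand for lower toxicity in this test and lower numbers for higher toxicity in this test), compound 1 gives > 33000 nM, which is a limit of the assay.
Compound 2: `CS(=O)(=O)Nc1ccc2c(c1)S(=O)(=O)N=C(C1=C(O)[C@H]3CCCC[C@H]3N(Cc3ccc(F)cc3)C1=O)N2`. In this assay compound 2 gives > 1000 nM, which is a limit of the assay.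
Compound 3: `CS(=O)(=O)Nc1ccc2c(c1)S(=O)(=O)N=C(C1=C(O)C3CCCCC3N(C3CCCCC3)C1=O)N2`. In this assay compound 3 gives > 33000 nM, which is a limit of the assay.

Compound 1 therefore stands at the limit of > 33000 nM in this assay, at which 2 of the 3 values shown sit, so for it no number is known, only that it lies beyond the range the test resolves. Among the measured compounds shown here, no two of the measured compounds differ from each other in a single place, so no measured step can be drawn between them.

The compound still to be measured is compound 4, `CS(=O)(=O)Nc1ccc2c(c1)S(=O)(=O)N=C(C1=C(O)C3CCCC3N(C3CCCCC3)C1=O)N2`. It is reached from compound 1 by the change (cyclohexyl in place of (pyridin-2-yl)methyl on an amide-type nitrogen in a ring). Compound 3 also carries a cyclohexyl on the amide-type nitrogen in its ring and, as stated, sits at the same limit. On this basis the step from compound 1 to compound 4 is expected to be none beyond the scatter, which a step that the limit leaves unreadable from compound 1 to compound 4 would express. Compound 4 is thus estimated at 40000 nM, with an expected range from 15000 nM to 100000 nM, and most likely to be reported again only as a limit.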

Compound 4, half-maximal cytotoxic concentration: > 10000 nM
Compound 4: only a limit was reported (the forecaster's own chance of this, stated with the estimate: 80%); the middle value does not contradict the limit.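

Among the compounds shown here, compound 1 and compound 4 are both reported only as limits in this assay, so cyclohexyl in place of (pyridin-2-yl)methyl gives no step that can be read. The compounds shown leave open at what concentration any of them would become toxic to these cells, and whether the substituent on the amide-type nitrogen affects that concentration.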